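Fluoro on the Fused Aromatic Ring: An Unmeasured Step

This account rests on a few compounds, and the source may have more. Where it says the series, first, only, none or still open, it means among the compounds named here.

Compound 3 `CSc1cc(C)[nH]c(=O)c1CNC(=O)c1c(C)n([C@H](C)[C@H]2CC[C@H](N3CC(OC4CC4)C3)CC2)c2ccccc12` gives 0.072 nM in an assay on Sf9 cells for inhibition of histone-lysine N-methyltransferase EZH2 (Homo sapiens), read by scintillation counting, with stated times of 5 h and 20 h (on this read-out higher numbers stand for weaker inhibition and lower numbers for stronger inhibition), the smallest of the three numbers shown, though every gap lies within the scatter: compound 2 `CSc1cc(C)[nH]c(=O)c1CNC(=O)c1c(C)n([C@H](C)[C@H]2CC[C@H](N3CC(OC(F)F)C3)CC2)c2ccccc12` gives 0.1 nM, compound 1 `CSc1cc(C)[nH]c(=O)c1CNC(=O)c1c(C)n([C@H](C)[C@H]2CC[C@H](N3CC(OC(F)(F)F)C3)CC2)c2ccccc12` gives 0.14 nM, and the steps are a 1.4-fold lower number from compound 2 to compound 3 (0.14 log units; within the scatter) and a 1.9-fold lower number from compound 1 to compound 3 (0.29 log units; within the scatter). Compound 4 `CSc1cc(C)[nH]c(=O)c1CNC(=O)c1c(C)n([C@H](C)[C@H]2CC[C@H](N3CC(OC4CC4)C3)CC2)c2c(F)cccc12` differs from compound 3 by fluoro in place of hydrogen on an aromatic carbon. Among the measured compounds shown here, none of the measured steps touches that place; all of them, including a 1.4-fold lower number from compound 1 to compound 2 (0.15 log units; within the scatter), concern the group on the oxygen on a saturated carbon, and each stayed within the scatter. The data give no direct guide, so no step beyond the scatter is expected in this assay. Compound 4 is estimated at 0.07 nM, between 0.03 nM and 0.2 nM. This implies an expected step of a 1.0-fold lower number from compound 3 to compound 4 (0.01 log units; within the scatter).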

Compound 4, half-maximal inhibitory concentration: 0.063 nM
Compound 4: middle estimate off by 1.1-fold (0.05 log units), on the high side; the measured number falls inside the stated range.
By their numbers in this assay, from the lowest: compounds 4, 3, 2 and 1 (each within the scatter of the next, the first and the last beyond it).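

Unlike the earlier steps, which all concern the group on the oxygen, this one changes the aromatic ring of the shared core: fluoro in place of hydrogen gives a 1.1-fold lower number from compound 3 to compound 4 (0.06 log units; within the scatter) in this assay. With cyclopropyl on the oxygen, this aromatic carbon therefore takes fluoro without a step beyond the scatter. Nothing shown bears on the reason for this result.

As far as these compounds go, whether chloro, methoxy or a nitrile on this carbon would also stay within the scatter remains open. So does the outcome of fluoro here alongside trifluoromethyl or difluoromethyl on the oxygen.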